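Dichlorophenoxy to methoxyphenylsulfanyl on a shared core

The compounds below may be only part of what the source reports. "The series", "measured", "known", "first", "only" and "open" are said of these compounds alone.

Of the compounds shown here, three sharing one core have been tested in a functional assay on SF-295 cells (Homo sapiens) for inhibition, read by sulforhodamine B assay, with a stated time of 48 h; a lower number here means that less compound is tolerated, a higher number that more compound is tolerated. Compound 1 `Nc1cc(N)c2nc(-c3ccccc3)c(Oc3ccc(Cl)c(Cl)c3)nc2c1` gives 69200 nM in this assay. Compound 2 `COc1ccc(CNc2nc3cc(N)cc(N)c3nc2-c2ccccc2)cc1OC` gives 58900 nM in this assay, and its number and that of compound 1 lie within the usual scatter of each other, so neither can be called the more or less tolerated. Compound 3 `CCOC(=O)[C@H](CCC(=O)O)NC(=O)c1ccc(Oc2nc3cc(N)cc(N)c3nc2-c2ccccc2)cc1` gives only a limit of this assay, < 100000 nM, and not a number. Thus one of the three values shown is a limit, (the limit of < 100000 nM in this assay, at which 1 of the 3 values shown sits).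

Compound 4 `COc1ccc(Sc2nc3cc(N)cc(N)c3nc2-c2ccccc2)cc1` has not yet been measured. It differs from compound 1 in one place: (4-methoxyphenyl)sulfanyl in place of 3,4-dichlorophenoxy on an aromatic carbon. Among the compounds with values here, no step between two measured compounds that differ in only one place is available, so nothing measured tells how this particular exchange shifts the number.

What the shown compounds suggest is that changes at this position of the core have so far left the numbers close together, as compound 1 and compound 2 show. Compound 4 is therefore expected to give about 60000 nM in this assay, with a range from 25000 nM to 150000 nM. The expected step of a 1.2-fold lower number from compound 1 to compound 4 (0.06 log units; within the scatter) is small, within the scatter, in no set direction.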

Compound 4, concentration lethal to 50% of the cells: < 100000 nM
Compound 4: a limit, no number; the forecaster's own chance of this, stated with the estimate: 30%; the middle value does not contradict the limit.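

In this assay compound 4 gives < 100000 nM, which is a limit of the assay and not a number, so no step can be read between compound 1 and compound 4. Whether (4-methoxyphenyl)sulfanyl in place of 3,4-dichlorophenoxy shifts the number at all, and in which direction, stays open because compound 4 sits at the same limit as compound 3: the limit of < 100000 nM in this assay, at which 2 of the 4 values shown sit.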